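The source may report more compounds than this note shows. Statements on the series, on what has been measured and on what is new or still open speak of the compounds shown alone.

Of the compounds shown here, two have been measured in a functional assay on HL-60 cells (Homo sapiens) for cytotoxicity, read by flow cytometry and annexin V staining, with a stated time of 18 h (on this read-out lower numbers stand for stronger inhibition and higher numbers for weaker inhibition), and one awaits measurement. Compound 1 `CCCCC/C=C/C=C/C(=O)N1CCCC1` reaches only the ceiling of this assay: its reading of > 50000 nM is a limit of the assay rather than a number (the limit of > 50000 nM in this assay, at which 1 of the 2 values shown sits). Compound 2 `C/C1=C\CC[C@@]2(C)O[C@@H]2[C@H]2OC(=O)[C@@H](CN=[N+]=[N-])[C@@H]2CC1` gives 4300 nM in this assay and thus holds the only number shown. Compound 3 `C/C1=C\CC[C@@]2(C)O[C@@H]2[C@H]2OC(=O)[C@@H](Cn3cc(CO)nn3)[C@@H]2CC1` differs from compound 2 in one place (4-(hydroxymethyl)-1H-1,2,3-triazol-1-yl in place of azido on a saturated chain carbon bound to a saturated ring carbon). Among the compounds with values here, no step between measured compounds is available, so the size of this change can only be judged from the change itself. The expected step is a 1.4-fold higher number from compound 2 to compound 3 (0.14 log units; within the scatter), which stays within the scatter or amounts at most to a slight weakening. Compound 3 is therefore expected to give about 6000 nM in this assay, within a range from 2000 nM to 20000 nM.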

Compound 3, half-maximal inhibitory concentration: > 50000 nM
Compound 3 was reported as a limit (the forecaster's own chance of this, stated with the estimate: 10%); at least 8.3-fold (0.92 log units) between middle value and limit.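

In this assay, within the data shown here, this is the first change measured at this position, a saturated chain carbon bound to a saturated ring carbon, and it is not neutral: 4-(hydroxymethyl)-1H-1,2,3-triazol-1-yl in place of azido gives an at least 11-fold higher number from compound 2 to compound 3 (1.06 log units; beyond the scatter). The shared core therefore does not keep its reading in this assay whatever group sits at this place. The reading of compound 3 is a limit and not a number, so the step gives only a lower bound on the change: the limit of > 50000 nM in this assay, at which 2 of the 3 values shown sit.

The compounds shown leave open whether the change follows from the triazole ring itself or from its hydroxymethyl group, which 4-methyl-1H-1,2,3-triazol-1-yl at the same place could separate. They also leave open how a primary amine in place of azido would read.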